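This account rests on a few compounds, and the source may have more. Where it says the series, first, only, none or still open, it means among the compounds named here.

Compound 2 `CC(=O)OCC1COCCOCCOCCOCCOCCO1`: > 100000 nM
Compound 1 `O=C(CCCCOc1ccccc1)OCC1COCCOCCOCCOCCOCCO1`: > 100000 nM

In a functional assay on HBL-100 cells (Homo sapiens) for inhibition, read by sulforhodamine B assay, with a stated time of 48 h (on this read-out lower numbers stand for stronger inhibition of growth and higher numbers for weaker inhibition of growth), compound 2 gives > 100000 nM, which is a limit of the assay rather than a number. Compound 1 likewise gives > 100000 nM, also a limit. Among the compounds with values here, the only measured step, a step that the two limits leave unreadable from compound 1 to compound 2, is therefore unreadable, since (the limit of > 100000 nM in this assay, at which 2 of the 2 values shown sit). Compound 3 `O=C(CCCc1cc2ccccc2[nH]1)OCC1COCCOCCOCCOCCOCCO1` arises from compound 2 by 2-(1H-indol-2-yl)ethyl in place of hydrogen on a saturated chain carbon bound to a carbonyl carbon. No readable step bears on this change, so no direction can be drawn in this assay. Compound 3 is estimated at 100000 nM (range 30000 nM to 300000 nM). The expected step from compound 2 to compound 3 is a number no higher from compound 2 to compound 3 (the limit leaves the size open).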

Compound 3, concentration for 50% growth inhibition: > 100000 nM
Compound 3: no number, only a limit; the forecaster's own chance of this, stated with the estimate: 65%; the middle value sits exactly at the limit.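

In this assay no new step can be read between compound 3 and compound 1 or compound 2, because all three stop at the same limit: the limit of > 100000 nM in this assay, at which 3 of the 3 values shown sit.

From the compounds shown here alone, how strongly each compound inhibits growth, and whether their different side chains matter, stays open.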